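Chloro to Bromo on the Pendant Phenyl Ring

The compounds below may be only part of what the source reports. "The series", "measured", "known", "first", "only" and "open" are said of these compounds alone.

Compound 3 `Clc1ccc(-c2cn3ccnc3c(-c3ccc4ncn(C5CCCCC5)c4c3)n2)cc1` stands second highest of three numbers in a functional assay on EKVX cells (Homo sapiens) for inhibition, read by sulforhodamine B assay, with a stated time of 48 h, tested at 10 uM (on this read-out higher numbers stand for more inhibition at the one concentration tested (going by the name of the read-out) and lower numbers for less inhibition), giving 13.1%. Compound 1 `COc1ccc(-c2cn3ccnc3c(-c3ccc4ncn(C5CCCCC5)c4c3)n2)cc1` gives 56.7%, and compound 2 `Fc1ccc(-c2cn3ccnc3c(-c3ccc4ncn(C5CCCCC5)c4c3)n2)cc1` gives 10.5%. The step of a number 43.6 percentage points lower from compound 1 to compound 3 (beyond the scatter) is large, whereas a number 2.6 percentage points higher from compound 2 to compound 3 (within the scatter) stays within the scatter. Compound 4 `Brc1ccc(-c2cn3ccnc3c(-c3ccc4ncn(C5CCCCC5)c4c3)n2)cc1` differs from compound 3 by bromo in place of chloro on an aromatic carbon. Going by the values given here, the one measured step that bears on this change, a number 2.6 percentage points higher from compound 2 to compound 3 (within the scatter), swapped one such group for another and was small, so no movement beyond the scatter is expected in this assay; the expected step is a number 2.9 percentage points higher from compound 3 to compound 4 (within the scatter). Compound 4 is therefore estimated to give 16% in this assay, within a range from 5% to 30%.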

Compound 4, a percentage reported as inhibition, at one concentration (the size of the read-out at that concentration, not a potency): 16.2%
Compound 4: middle estimate off by 0.2 percentage points, on the low side, within the range that was stated.
By their numbers in this assay, from the lowest: compounds 2, 3 and 4 (each within the scatter of the next); then compound 1.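

In this assay the steps of a number 3.1 percentage points higher from compound 3 to compound 4 (within the scatter) and a number 5.7 percentage points higher from compound 2 to compound 4 (within the scatter) show that bromo joins fluoro and chloro in a set of values that cannot be told apart at this position. Bromo also stays far from methoxy, with a number 40.5 percentage points lower from compound 1 to compound 4 (beyond the scatter) as the step, so among these four compounds only compound 1 stands apart. No measurement at hand explains that gap. Going by these compounds, whether the higher number is tied to methoxy itself stays open: a hydroxyl, an ethoxy group or an amine on this carbon would bear on that.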